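Replacing a sulfonamide with a pyrazole on a fused bicyclic core

The source may hold more compounds than are shown below. What is called first, only, known or untested is meant among the compounds shown, and "the series" means these compounds.

Measured compounds:
compound 1, `CS(=O)(=O)Nc1cccc2c1CCC2c1ncc[nH]1`, gives 87%
compound 2, `Cc1c(OCC2=NCCN2)ccc(Cl)c1NS(C)(=O)=O`, gives 60%

In a functional assay on CHO cells for agonist activity at Alpha-1A adrenergic receptor (Homo sapiens), read by FLIPR and calcium flux (a lower number here means a smaller maximal response, a higher number a larger maximal response), compound 1 stands highest of the two numbers shown; compound 2 is the nearest, and its value lies lower by more than the usual scatter. Compound 3, `Cc1n[nH]cc1-c1cccc2c1CCC2c1ncc[nH]1`, has not yet been measured. It keeps the core of compound 1 and differs in one place: 3-methyl-1H-pyrazol-4-yl in place of methanesulfonamido on an aromatic carbon. Among the compounds with values here, no two measured compounds differ by only this change, so no measured step tells how large its effect is. Compound 2 carries the same methanesulfonamido group as compound 1 but on a different core, so its lower value cannot be traced to that group alone. For compound 3 a step of a number 12 percentage points lower from compound 1 to compound 3 (beyond the scatter) is expected, a modest decrease that may still lie within the scatter. The value expected for compound 3 is 75%, with a range from 40% to 100%.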

Compound 3, largest response reached (Emax), in percent of the reference or control that the assay uses: 91%
For compound 3 the middle estimate is 16 percentage points below the measured one; the measured number falls inside the stated range.
By their numbers in this assay, from the lowest: compound 2; then compounds 1 and 3 (each within the scatter of the next).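

In this assay, putting 3-methyl-1H-pyrazol-4-yl in place of methanesulfonamido on the aromatic carbon of the shared core gives a number 4 percentage points higher from compound 1 to compound 3 (within the scatter). Within the data shown here, this pair is the first direct reading of the change: on this core, the maximal response stays within the usual scatter when the sulfonamide group gives way to a five-membered aromatic ring with 2 hetero atoms, so this one replacement can be made without a measurable loss in this read-out. Nothing shown here explains why the two groups give such similar responses.

Still open, as far as these compounds go, is whether the same exchange would hold on the different core of compound 2, which also carries methanesulfonamido. From the compounds shown here alone, it is also open whether a simple amine, a carboxylic acid or a pyrazole lacking the methyl group would give a similar response at this place.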